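Methoxy for fluoro on the carbonyl-linked phenyl

This account rests on a few compounds, and the source may have more. Where it says the series, first, only, none or still open, it means among the compounds named here.

Measured so far in an assay on isolated protein for inhibition of polyamine deacetylase HDAC10 (Homo sapiens); a lower number here means a stronger inhibitor, a higher number a weaker inhibitor:
compound 1 `COc1ccc(C(=O)c2ccc3c(ccn3Cc3ccc(C(=O)NO)cc3)c2)cc1OC` gives 18900 nM
compound 2 `O=C(NO)c1ccc(Cn2ccc3cc(C(=O)c4ccc(F)cc4)ccc32)cc1` gives > 100000 nM
compound 3 `COc1cccc(C(=O)c2ccc3c(ccn3S(=O)(=O)c3cccc(/C=C/C(=O)NO)c3)c2)c1` gives 7740 nM

Compound 2 is known in this assay only by a limit, > 100000 nM, and no number. Of the three values shown, one sits at the limit of > 100000 nM in this assay, at which 1 of the 3 values shown sits. Compound 1 and compound 3 are the two compounds with numbers; the reading for compound 3 is the lower of the two.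

Compound 4 `COc1ccc(C(=O)c2ccc3c(ccn3Cc3ccc(C(=O)NO)cc3)c2)cc1` has not yet been measured. It differs from compound 2 by methoxy in place of fluoro on an aromatic carbon. Within the data shown here, the one measured step that bears on this change is an at least 5.2-fold higher number from compound 1 to compound 2 (0.72 log units; beyond the scatter), where both methoxy groups of compound 1 gave way to a single fluoro and the number rose at least modestly. Compound 4 puts one of those methoxy groups back in the position the fluoro occupies, so a part of that step is expected to reverse: a lower number than the limit of compound 2, though probably not all the way to compound 1. The step expected for compound 4 is an at least 2.5-fold lower number from compound 2 to compound 4 (0.39 log units; beyond the scatter). Compound 4 is estimated at 40000 nM, with a range from 15000 nM to 100000 nM.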

Compound 4, half-maximal inhibitory concentration: 59800 nM
Compound 4: the middle estimate sits 1.5-fold (0.17 log units) below what was measured; low and high end bracket the measured number.
By their numbers in this assay, from the lowest: compound 3; then compound 1; then compound 4. At a limit, above all of these: compound 2.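

Compound 4 separates the two methoxy groups that the earlier step from compound 1 to compound 2 changed together. In this assay, the loss of one methoxy alone, taking 3,4-dimethoxyphenyl to 4-methoxyphenyl on the carbonyl, gives a 3.2-fold higher number from compound 1 to compound 4 (0.50 log units; beyond the scatter), so the second methoxy counts on its own in this series. Compound 2 is known only by a limit: the limit of > 100000 nM in this assay, at which 1 of the 4 values shown sits.

With methoxy in place of fluoro, the reading is an at least 1.6-fold lower number from compound 2 to compound 4 (0.22 log units; that floor lies within the scatter); this floor does not by itself establish a gain from that exchange, although the true gap could be larger, and compound 4 does at least give a number where compound 2 gives none.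

Still open, on these data alone, is whether a hydroxyl, an amine or a methyl on the same aromatic carbon would read like methoxy or like fluoro, and whether an unsubstituted phenyl would lie lower or higher than either. Also open, as far as these compounds go, is whether the same methoxy dependence holds with the sulfonyl link and the unsaturated hydroxamic acid chain of compound 3, which differs from the others in more than one place.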